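From Cyanophenyl to Difluorophenyl on a Shared Core

A few compounds are considered here, and "the series" means these few. Any claim that something is new, unique, unknown or untested is made for them only; others in the source may bear on it.

For the measured compounds named here, the three compounds measured so far share one core and differ only in the group on a saturated chain carbon bound to an aromatic carbon. Compound 1 `O=C(O)c1ccccc1-c1ccc(CCc2ncc(Cc3ccccc3Cl)[nH]2)cc1` carries a 2-chlorophenyl there and gives 22 nM in an in vitro functional assay on cells for agonist activity at Bombesin receptor subtype-3 (Mus musculus), read by luminescence and calcium flux; on this read-out higher numbers stand for an effect only at larger amounts of compound and lower numbers for an effect already at smaller amounts. Compound 2 `CC(C)(C)Cc1cnc(CCc2ccc(-c3ccccc3C(=O)O)cc2)[nH]1` carries a tert-butyl and gives 6.3 nM in this assay. Compound 3 `N#Cc1cccc(Cc2cnc(CCc3ccc(-c4ccccc4C(=O)O)cc3)[nH]2)c1` carries a 3-cyanophenyl and gives 20 nM in this assay. Compound 3 thus stands second highest of the three numbers: its value and that of compound 1 lie within the scatter of each other, while its step from compound 2 is beyond it.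

Compound 4 `O=C(O)c1ccccc1-c1ccc(CCc2ncc(Cc3cccc(F)c3F)[nH]2)cc1` differs from compound 3 in one place: 2,3-difluorophenyl in place of 3-cyanophenyl on a saturated chain carbon bound to an aromatic carbon. All three measured steps bear on this position. Going by the values given here, the two that involve the tert-butyl, a 3.5-fold lower number from compound 1 to compound 2 (0.54 log units; beyond the scatter) and a 3.2-fold higher number from compound 2 to compound 3 (0.50 log units; beyond the scatter), were modest and beyond the scatter, whereas the only step that exchanges one substituted phenyl for another, a 1.1-fold lower number from compound 1 to compound 3 (0.04 log units; within the scatter), stayed within it. The change to compound 4 is again one substituted phenyl for another. The step expected for compound 4, a 1.1-fold lower number from compound 3 to compound 4 (0.05 log units; within the scatter), is therefore none beyond the scatter. Compound 4 is estimated at 18 nM, with a range from 8 nM to 45 nM.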

Compound 4, half-maximal effective concentration: 8 nM
Beside the measured number, compound 4's estimate is 2.3-fold (0.35 log units) above it, within the range that was stated.
By their numbers in this assay, from the lowest: compounds 2 and 4 (each within the scatter of the next); then compounds 3 and 1 (each within the scatter of the next).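

Exchanging one substituted phenyl for another on a saturated chain carbon bound to an aromatic carbon is not always neutral in this assay since 2,3-difluorophenyl in place of 3-cyanophenyl gives a 2.5-fold lower number from compound 3 to compound 4 (0.40 log units; beyond the scatter) and 2,3-difluorophenyl in place of 2-chlorophenyl gives a 2.8-fold lower number from compound 1 to compound 4 (0.44 log units; beyond the scatter) while the earlier exchange between substituted phenyl groups stayed within the scatter. A substituted phenyl can also sit level with the tert-butyl, as 2,3-difluorophenyl in place of tert-butyl gives a 1.3-fold higher number from compound 2 to compound 4 (0.10 log units; within the scatter) and so stays within the scatter, although compounds 1 and 3 show that other substituted phenyl groups do not. Nothing available accounts for the difference between 2,3-difluorophenyl and the other two substituted phenyl groups.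

The compounds shown leave open whether a single fluorine, as in 2-fluorophenyl or 3-fluorophenyl, would read like compound 4 or whether the 2,3-difluorophenyl pattern as a whole is needed. They also leave open how an amine, a carboxylic acid or a longer chain would read at this place in this assay on the same shared core.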